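The source may hold more compounds than are shown below. What is called first, only, known or untested is meant among the compounds shown, and "the series" means these compounds.

Measured so far in a functional assay on VCaP cells (Homo sapiens) for antiproliferative activity, read by propidium iodide staining, with a stated time of 96 h; on this read-out higher numbers stand for weaker inhibition and lower numbers for stronger inhibition:

Compound 1, `CC(O)(CSc1cc(C(F)(F)F)cc(C(F)(F)F)c1)C(=O)Nc1cccc(S(F)(F)(F)(F)F)c1`, 4000 nM
Compound 2, `CC(O)(COc1cccc(S(F)(F)(F)(F)F)c1)C(=O)Nc1cc(C(F)(F)F)cc(C(F)(F)F)c1`, 2700 nM
Compound 3, `CC(O)(COc1cccc(C(F)(F)C(F)(F)F)c1)C(=O)Nc1cc(C(F)(F)F)cc(C(F)(F)F)c1`, 9500 nM

Compounds 2 and 3 share a core and differ in one place: a group of 7 heavy atoms (2 carbon, 5 fluorine; no ring) in place of a group of 6 heavy atoms (5 fluorine, 1 sulfur; no ring), on an aromatic carbon. This change gave a 3.5-fold higher number from compound 2 to compound 3 (0.55 log units; beyond the scatter), a single precedent for the exchange. Compound 1 has a different core from compound 2; the difference between the two cores is not broken down here. The values of compound 1 and compound 2 in this assay lie within the scatter of each other, and compound 3 sits beyond compound 1 with the highest number of the three.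

Compound 4, `CC(O)(CSc1cc(C(F)(F)F)cc(C(F)(F)F)c1)C(=O)Nc1cccc(C(F)(F)C(F)(F)F)c1`, is not yet measured. It carries the same change on the core of compound 1: a group of 7 heavy atoms (2 carbon, 5 fluorine; no ring) in place of a group of 6 heavy atoms (5 fluorine, 1 sulfur; no ring), on an aromatic carbon. Among the compounds with values here, with only the pair of compound 2 and compound 3 to go on, a step of similar size is expected from compound 1, so a 3.3-fold higher number from compound 1 to compound 4 (0.51 log units; beyond the scatter) is estimated, resting on a 3.5-fold higher number from compound 2 to compound 3 (0.55 log units; beyond the scatter). Compound 4 is therefore expected to give about 13000 nM in this assay, with 5000 nM to 35000 nM as the plausible range.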

Compound 4, half-maximal inhibitory concentration: 8600 nM
Estimate against measurement, compound 4: 1.5-fold (0.18 log units) above; the range from low to high includes it.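

In this assay, 1,1,2,2,2-pentafluoroethyl in place of the fluorine-and-sulfur group gave a 2.2-fold higher number from compound 1 to compound 4 (0.33 log units; beyond the scatter). Within the data shown here, the change raises the number on both cores, and the two steps do not differ by more than the scatter of such steps: the same change on two cores in this assay, a 3.5-fold higher number (0.55 log units; beyond the scatter) from compound 2 to compound 3 and a 2.2-fold higher number (0.33 log units; beyond the scatter) from compound 1 to compound 4, 1.6-fold (0.21 log units) apart, within the scatter of two such steps This supports carrying the exchange between these two cores as a step of similar size, but it rests on only two pairs in one assay, so it does not show that the step would hold on a further core, and it gives no reason for the rise.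

The compounds shown leave open how other groups on this aromatic carbon would compare, such as a nitrile, an amine or a longer chain like heptafluoropropyl, and whether any of them would give a lower number than the fluorine-and-sulfur group on either core. Also open, from the compounds shown here alone, is whether the same step appears on any read-out other than this antiproliferative one.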